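A Hydrogen Atom in Place of a Large Group

The source may hold more compounds than are shown below. What is called first, only, known or untested is meant among the compounds shown, and "the series" means these compounds.

In a functional assay on MCF7 cells (Homo sapiens) for inhibition, read by MTT assay, with a stated time of 48 h (on this read-out higher numbers stand for weaker inhibition and lower numbers for stronger inhibition), compound 1 `CCOC(=O)C1=C(N/N=C(\C#N)C(N)=O)Nc2[nH]nc(C)c2C1c1ccc(N(C)C)cc1` gives 50100 nM. Within the data shown here, compound 2 `CCOC(=O)C1=C(N/N=C(/Cl)c2ccc([N+](=O)[O-])cc2)Nc2[nH]nc(C)c2C1c1ccc(N(C)C)cc1` gives 52700 nM, which places it level with compound 1, the only other compound measured so far. Compound 3 `CCOC(=O)C1=C(N)Nc2[nH]nc(C)c2C1c1ccc(N(C)C)cc1` departs from compound 2 by a single change: a hydrogen atom in place of a group of 12 heavy atoms (7 carbon, 2 nitrogen, 2 oxygen, 1 chlorine; one six-membered aromatic ring of carbon only), on an amine nitrogen. Among the measured compounds shown here, one measured step bears on this amine nitrogen: a 1.1-fold higher number from compound 1 to compound 2 (0.02 log units; within the scatter), which stays within the scatter even though the two groups differ in size. For the measured compounds named here, that step offers only partial guidance, since no measured compound carries a hydrogen atom at this place and the effect of removing the group outright is untested. No shift beyond the scatter is therefore expected, and the estimated step is a 1.1-fold lower number from compound 2 to compound 3 (0.02 log units; within the scatter). Compound 3 is expected at 50000 nM, with an estimated range of 20000 nM to 120000 nM.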

Compound 3, half-maximal inhibitory concentration: 5060 nM
Beside the measured number, compound 3's estimate is 9.9-fold (0.99 log units) above it; measured number outside the range, below it.
By their numbers in this assay, from the lowest: compound 3; then compounds 1 and 2 (each within the scatter of the next).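

In this assay the hydrogen atom on this amine nitrogen brings a clear change, with a 10-fold lower number from compound 2 to compound 3 (1.02 log units; beyond the scatter) on losing the group of 12 heavy atoms and a 9.9-fold lower number from compound 1 to compound 3 (1.00 log units; beyond the scatter) on losing the group of 7 heavy atoms. The earlier pair had shown only that these two groups stand level with each other, while these steps show that, among these three compounds, having either group at this place counts for more than which of the two it is. Nothing measured here explains the change.

As far as these compounds go, it remains open whether a small group on this nitrogen, such as a methyl or an acetyl group, keeps the lower number of compound 3. From the compounds shown here alone, it is equally open whether such a group would instead return to the level of compound 1 and compound 2.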